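The compounds below may be only part of what the source reports. "The series", "measured", "known", "first", "only" and "open" are said of these compounds alone.

Measured compounds:
- compound 1, `CCC(=O)N1CCC(CN(C2Cc3cc(C#N)ccc3N(Cc3cncn3C)C2)S(=O)(=O)c2ccccn2)CC1`: 0.5 10^-6 cm/s
- compound 2, `C=C(C)C(=O)N1CCC(CN(C2Cc3cc(C#N)ccc3N(Cc3cncn3C)C2)S(=O)(=O)c2ccccn2)CC1`: 0.5 10^-6 cm/s
- compound 3, `Cc1noc(C)c1CN(C1Cc2cc(C#N)ccc2N(Cc2cncn2C)C1)S(=O)(=O)c1ccccn1`: 8 10^-6 cm/s

In an ADME assay on Caco-2 cells (Homo sapiens) for permeability, in the apical to basolateral direction (a lower number here means that the compound crosses the layer more slowly, a higher number that the compound crosses the layer faster), compound 3 stands highest of the three numbers. Compound 1 gives 0.5 10^-6 cm/s and compound 2 gives 0.5 10^-6 cm/s in this assay, and between them there is no change at the digits printed from compound 1 to compound 2 (within the scatter). The rise to compound 3 is large in both cases: a 16-fold higher number from compound 1 to compound 3 (1.20 log units; beyond the scatter) and a 16-fold higher number from compound 2 to compound 3 (1.20 log units; beyond the scatter).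

Compound 4, `Cn1cncc1CN1CC(N(Cc2cccc(-n3cccc3)c2)S(=O)(=O)c2ccccn2)Cc2cc(C#N)ccc21`, is not yet measured in this assay. It differs from compound 3 as follows: 3-(1H-pyrrol-1-yl)phenyl in place of 3,5-dimethyl-1,2-oxazol-4-yl on a saturated chain carbon bound to a sulfonamide nitrogen. Among the measured compounds shown here, no measured step exchanges one aromatic group for another on the saturated chain carbon bound to the sulfonamide nitrogen; the two measured steps only show that compound 3 sits far above compounds 1 and 2 once the 1-propanoylpiperidin-4-yl or 1-((1-methylethenyl)carbonyl)piperidin-4-yl group is gone. Since compound 4 keeps an aromatic group in that place, its number is expected to stay near that of compound 3, with a step of a 1.3-fold higher number from compound 3 to compound 4 (0.10 log units; within the scatter) expected. Compound 4 is therefore estimated at 10 10^-6 cm/s, in the range 4 10^-6 cm/s to 25 10^-6 cm/s.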

Compound 4, apparent permeability: 2.3 10^-6 cm/s
Beside the measured number, compound 4's estimate is 4.3-fold (0.64 log units) above it; measured number outside the range, below it.
By their numbers in this assay, from the lowest: compounds 1 and 2 (each within the scatter of the next); then compound 4; then compound 3.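

In this assay, the place on a saturated chain carbon bound to a sulfonamide nitrogen now separates two aromatic groups: 3-(1H-pyrrol-1-yl)phenyl in place of 3,5-dimethyl-1,2-oxazol-4-yl gives a 3.5-fold lower number from compound 3 to compound 4 (0.54 log units; beyond the scatter) and so keeping an aromatic group there does not alone hold the number at the level of compound 3. The same group still stands clear of both acylated piperidines, with a 4.6-fold higher number from compound 1 to compound 4 (0.66 log units; beyond the scatter) and a 4.6-fold higher number from compound 2 to compound 4 (0.66 log units; beyond the scatter) as the steps, so compound 4 falls in the interval that compound 3 alone had marked out above them. Nothing at hand bears on why these steps have the sizes they do.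

On these data alone, whether a plain phenyl group in this place would stand nearer compound 3 or compound 4 stays open. Also open, as far as these compounds go, is where a benzyl carrying a primary amine or a carboxylic acid would fall.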